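The source may hold more compounds than are shown below. What is called first, only, known or untested is meant among the compounds shown, and "the series" means these compounds.

Three measured compounds share one core. Compound 1 `CCOC(=O)c1c(-c2ccccc2)nn(-c2ccccc2)c1Cn1c(Cl)nc2ccccc21` carries a chloro group on its fused ring system, and in an assay for inhibition of Alpha amylase (Homo sapiens), with a stated time of 30 min (on this read-out lower numbers stand for stronger inhibition and higher numbers for weaker inhibition), compound 1 gives 10 ug/mL. Compound 2 `CCOC(=O)c1c(-c2ccccc2)nn(-c2ccccc2)c1Cn1cnc2ccccc21` has hydrogen in that place, and in this assay compound 2 gives 35 ug/mL. Compound 3 `CCOC(=O)c1c(-c2ccccc2)nn(-c2ccccc2)c1COc1cc(OC)c(C=O)c(OC)c1` replaces the whole fused ring system with a substituted aromatic ether, and in this assay compound 3 gives 40 ug/mL. Compound 2 therefore stands second highest of the three numbers: its value and that of compound 3 lie within the scatter of each other, while the step of a 3.5-fold higher number from compound 1 to compound 2 (0.54 log units; beyond the scatter) is the only one beyond the scatter.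

Compound 4 `CCOC(=O)c1c(-c2ccccc2)nn(-c2ccccc2)c1Cn1cnc2cc([N+](=O)[O-])ccc21` differs from compound 2 by nitro in place of hydrogen on an aromatic carbon. Within the data shown here, no measured step touches that position; the step from compound 1 to compound 2 concerns a different carbon of the same fused ring system and is only modest. Among the measured compounds shown here, with no direct precedent, compound 4 is expected to show no step beyond the scatter, written as a 1.4-fold lower number from compound 2 to compound 4 (0.15 log units; within the scatter). The estimate for compound 4 is 25 ug/mL, expected to fall between 8 ug/mL and 70 ug/mL.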

Compound 4, half-maximal inhibitory concentration: 30 ug/mL
Compound 4: middle estimate off by 1.2-fold (0.08 log units), on the low side; low and high end bracket the measured number.
By their numbers in this assay, from the lowest: compound 1; then compounds 4, 2 and 3 (each within the scatter of the next).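

The step of a 1.2-fold lower number from compound 2 to compound 4 (0.07 log units; within the scatter) in this assay shows that, on this carbon of the six-membered aromatic ring, nitro with its 3 heavy atoms can take the place of hydrogen without a difference that can be told from the scatter. Among these compounds, this is the first view of this position, and it contrasts with the step of a 3.5-fold higher number from compound 1 to compound 2 (0.54 log units; beyond the scatter) on another carbon of the fused system, which involves chloro and lies beyond the scatter. Nothing available explains this result.

The compounds shown leave open whether an amine or a carboxylic acid on this same carbon would also stay within the scatter. They also leave open whether nitro would give a similar result if the chloro group of compound 1 were present.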